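Furan for Thiophene on the Chain of Compound 1

A few compounds are considered here, and "the series" means these few. Any claim that something is new, unique, unknown or untested is made for them only; others in the source may bear on it.

Measured compounds:
compound 1 `O=C(/C=C/c1ccsc1)c1cc(O)c(O)c([N+](=O)[O-])c1`, 230 nM
compound 2 `N#Cc1ccc(/C=C/C(=O)c2cc(O)c(O)c([N+](=O)[O-])c2)cc1`, 180 nM
compound 3 `CC(=O)N1N=C(c2cc(O)c(O)c([N+](=O)[O-])c2)CC1c1ccoc1`, 180 nM

In an assay for inhibition of Catechol O-methyltransferase (Rattus norvegicus), read by fluorescence and spectrophotometry (a higher number here means a weaker inhibitor, a lower number a stronger inhibitor), compound 1 gives 230 nM. Its number is the highest of the three, yet compound 2 with 180 nM and compound 3 with 180 nM both sit within the usual scatter of it, so the three measured compounds cannot be told apart on these numbers. For the measured compounds named here, no two of them differ in only one place, so no step between measured compounds is available to lean on.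

Compound 4 `O=C(/C=C/c1ccco1)c1cc(O)c(O)c([N+](=O)[O-])c1` is the unmeasured compound. It differs from compound 1 by furan-2-yl in place of thiophen-3-yl on a double-bonded chain carbon bound to a double-bonded chain carbon. The shared core of compound 1 stays untouched, and what changes is one five-membered aromatic ring for another of the same size and with the same count of heavy atoms, donors and acceptors.

With no measured step of this kind in hand, the step from compound 1 to compound 4 in this assay is expected to be small, with no clear direction, and to stay within the scatter: no change at the digits printed from compound 1 to compound 4 (within the scatter). Compound 4 is therefore estimated at 230 nM in this assay, within a range from 100 nM to 550 nM.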

Compound 4, half-maximal inhibitory concentration: 230 nM
Estimate against measurement, compound 4: no gap at the digits printed, within the range that was stated.
By their numbers in this assay, from the lowest: compounds 2, 3, 1 and 4 (each within the scatter of the next).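

In this assay, for the compounds shown here, the step of no change at the digits printed from compound 1 to compound 4 (within the scatter) is the first comparison in this set between two compounds that differ in one place, which the three earlier compounds could not offer. It shows that, on a double-bonded chain carbon bound to a double-bonded chain carbon, furan-2-yl can take the place of thiophen-3-yl with no change at the digits printed, even though the hetero atom and the point of attachment of the ring differ together. Nothing measured here accounts for this result, which stands as a plain observation about these two groups at this one place.

The compounds shown leave open whether the hetero atom or the point of attachment matters on its own, since a single step changes both, and thiophen-2-yl or furan-3-yl on the same chain carbon would pull the two apart. They also leave open how far this tolerance reaches beyond five-membered aromatic rings, for instance to an amine or a carboxylic acid in the same place on the chain.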